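Pyridin-3-yl in Place of Phenylethenyl on the Oxadiazole Carbon

This account rests on a few compounds, and the source may have more. Where it says the series, first, only, none or still open, it means among the compounds named here.

Compound 3, `COc1nc2ccccc2cc1/C=C/c1noc(/C=C/c2ccccc2)n1`, belongs to a set of three compounds that share one core and differ only in the group carried on the five-membered ring. In an ADME assay on HepG2 cells (Homo sapiens) for cytotoxicity, read by sulforhodamine B assay, with a stated time of 48 h (a lower number here means that less compound is tolerated, a higher number that more compound is tolerated), compound 3 reaches only a limit, > 225000 nM. Compound 1, `COc1nc2ccccc2cc1/C=C/c1noc(-c2cccc(C)c2)n1`, likewise reaches only a limit in this assay, > 230000 nM. Compound 2, `COc1nc2ccccc2cc1/C=C/c1noc(-c2cccc(Cl)c2)n1`, also gives no number but a limit, > 220000 nM. All three values sit at the limit of > 220000 nM in this assay, at which 1 of the 3 values shown sits, the limit of > 225000 nM in this assay, at which 1 of the 3 values shown sits, and (the limit of > 230000 nM in this assay, at which 1 of the 3 values shown sits), so every step among them is unreadable: a step that the two limits leave unreadable from compound 1 to compound 2, a step that the two limits leave unreadable from compound 1 to compound 3 and a step that the two limits leave unreadable from compound 2 to compound 3. Compound 4, `COc1nc2ccccc2cc1/C=C/c1noc(-c2cccnc2)n1`, differs from compound 3 by pyridin-3-yl in place of 2-phenylethenyl on an aromatic carbon. The steps from compound 1 and from compound 2 to compound 3 exchange the group on the same ring carbon and so bear on this change, yet neither has a readable size. No step beyond the scatter is therefore expected in this assay, a number no higher from compound 3 to compound 4 (the limit leaves the size open). Compound 4 is expected to give again only a limit, estimated at 225000 nM, between 100000 nM and 300000 nM.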

Compound 4, half-maximal cytotoxic concentration: > 240000 nM
Compound 4 was reported as a limit; the forecaster's own chance of this, stated with the estimate: 85%; middle value at least 1.0-fold (0.02 log units) from the limit.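

Compound 4, like compound 1, compound 2 and compound 3, gives only a limit in this assay, so none of the steps linking it to those three compounds can be read. The compounds shown leave open whether changing this group alters cytotoxicity at all.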